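Swapping a difluorophenyl for a dichlorophenyl on the shared core

This account rests on a few compounds, and the source may have more. Where it says the series, first, only, none or still open, it means among the compounds named here.

Measured compounds:
Compound 1, `CN1CCN(CCCOc2cccc3nc(Nc4ccc(Cl)c(F)c4)ccc23)CC1`: 1760 nM
Compound 2, `CN1CCN(CCCOc2cccc3nc(Nc4ccc(F)c(F)c4)ccc23)CC1`: 3830 nM

The two compounds share a core and differ only in the halogens on the anilino ring. Among the measured compounds shown here, in a functional assay on PC-3 cells (Homo sapiens) for inhibition, read by sulforhodamine B assay, with a stated time of 48 h (a lower number here means a stronger inhibitor of growth, a higher number a weaker inhibitor of growth), compound 2 gives the higher of the two numbers, and the single step between them, a 2.2-fold higher number from compound 1 to compound 2 (0.34 log units; beyond the scatter), is a modest one beyond the scatter.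

Compound 3, `CN1CCN(CCCOc2cccc3nc(Nc4cc(Cl)cc(Cl)c4)ccc23)CC1`, is the next compound in line. The change from compound 2 is 3,5-dichlorophenyl in place of 3,4-difluorophenyl on a nitrogen on an aromatic ring. For the measured compounds named here, only one measured step bears on it: a 2.2-fold higher number from compound 1 to compound 2 (0.34 log units; beyond the scatter), where fluoro in place of chloro raised the number. Going by the values given here, compound 3 reverses that halogen choice twice over, but it also moves the substitution pattern to a 3,5-dichlorophenyl, for which no measured compound offers a comparison. The author therefore expects a step in this assay from compound 2 towards a lower number, of a size comparable to the measured step, with a wide range to cover the unknown pattern. For compound 3 the expected step is a 1.9-fold lower number from compound 2 to compound 3 (0.28 log units; within the scatter). The estimate for compound 3 is 2000 nM, within 600 nM to 7000 nM.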

Compound 3, concentration for 50% growth inhibition: 1760 nM
Compound 3: middle estimate off by 1.1-fold (0.06 log units), on the high side, and the stated range covers the measured number.
By their numbers in this assay, from the lowest: compounds 1 and 3 (each within the scatter of the next); then compound 2.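

Among the compounds shown here, replacing the 3,4-difluorophenyl with a 3,5-dichlorophenyl on this nitrogen gives, in this assay, a 2.2-fold lower number from compound 2 to compound 3 (0.34 log units; beyond the scatter), so the step from compound 1 to compound 2 is no longer the only measured change in this ring that separates two compounds beyond the scatter. Compared with the 4-chloro-3-fluorophenyl group, the 3,5-dichlorophenyl group shows no change at the digits printed from compound 1 to compound 3 (within the scatter): two aryl groups with different halogens and different substitution patterns give the same printed number, and among these three compounds only compound 2, the one without chlorine, stands apart. Nothing given here accounts for this result or explains why compound 2 differs from the other two compounds.

In the step to compound 3, the kind of halogen and the substitution pattern change together, so the compounds shown cannot separate the contribution of either one. On these data alone, it also remains open whether a ring carrying a nitrile or a methoxy group in place of the halogens would stay level with compound 1 and compound 3 or move away from them in this assay.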